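A few compounds are considered here, and "the series" means these few. Any claim that something is new, unique, unknown or untested is made for them only; others in the source may bear on it.

Compound 1 `COCC(C)(C)C#Cc1c(Cl)c2c(Cl)cc(C(N)=O)nc2n1[C@H]1CCCNC1` is the starting point of this step. Among the measured compounds shown here, in a functional assay on KG-1 cells (Homo sapiens) for antiproliferative activity (a higher number here means that more compound is needed for the effect, a lower number that less compound is needed), compound 1 gives 219 nM, the highest of the two single numbers in the set; the only neighbour with a single number is compound 2 `NC(=O)c1cc(Cl)c2c(Cl)c(C#CCCO)n([C@H]3CCCNC3)c2n1`, which gives 56 nM. The step between them, a 3.9-fold lower number from compound 1 to compound 2 (0.59 log units; beyond the scatter), comes from putting 2-hydroxyethyl in place of 1-(methoxymethyl)-1-methylethyl on a triple-bonded carbon. Compound 3 `NC(=O)c1cc(Cl)c2c(Cl)c(C#CC3COCCO3)n([C@H]3CCCNC3)c2n1` has been measured twice and gives 77 nM; 203 nM (2 entries); the spread in the several entries of compound 3 in this assay, 77 nM; 203 nM (2 entries) shows how far repeat readings of one compound can lie apart, so single numbers deserve caution.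

Compound 4 `CC(C)(CC#Cc1c(Cl)c2c(Cl)cc(C(N)=O)nc2n1[C@H]1CCCNC1)C(N)=O` is not yet measured. It differs from compound 1 as follows: 2-carbamoyl-2-methylpropyl in place of 1-(methoxymethyl)-1-methylethyl on a triple-bonded carbon. For the measured compounds named here, the only measured step that bears on this position, a 3.9-fold lower number from compound 1 to compound 2 (0.59 log units; beyond the scatter), was modest and went toward a lower number when the branched ether was replaced by a smaller group carrying a hydrogen-bond donor. Compound 4 keeps a branched chain but gains a hydrogen-bond donor, so a smaller move in the same direction is expected, a 1.8-fold lower number from compound 1 to compound 4 (0.26 log units; within the scatter). The estimate for compound 4 is therefore 120 nM, with a range from 45 nM to 320 nM.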

Compound 4, half-maximal effective concentration: 269 nM
For compound 4 the middle estimate is 2.2-fold (0.35 log units) below the measured one; low and high end bracket the measured number.
By their numbers in this assay, from the lowest: compound 2; then compounds 1 and 4 (each within the scatter of the next).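

In this assay, the 2-carbamoyl-2-methylpropyl group in place of 1-(methoxymethyl)-1-methylethyl gives a 1.2-fold higher number from compound 1 to compound 4 (0.09 log units; within the scatter), so adding a hydrogen-bond donor to a branched chain at this position does not by itself reproduce the lower number seen with the hydroxyl chain. Set against that hydroxyl chain, the amide chain gives a 4.8-fold higher number from compound 2 to compound 4 (0.68 log units; beyond the scatter), which shows that among compounds with a single number, the lower reading so far belongs to the unbranched 2-hydroxyethyl group alone, while the two branched chains remain within the scatter of each other. Compound 3 cannot be placed firmly in this order, and its repeat readings show how wide the uncertainty around a single reading can be: the several entries of compound 3 in this assay, 77 nM; 203 nM (2 entries)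

The compounds shown leave open whether the lower number of compound 2 follows from its shorter, unbranched chain or from its hydroxyl group, since the two differences always come together here. A branched chain ending in a hydroxyl group, or an unbranched chain ending in a primary amide, an amine or a carboxylic acid, would help separate these two features.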